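This account rests on a few compounds, and the source may have more. Where it says the series, first, only, none or still open, it means among the compounds named here.

Measured compounds:
compound 1 `Cc1cnc(CN2CC(=O)N(CC(C)C)c3c(Cl)nc(N)nc32)c(C)c1Br` gives 130 nM
compound 2 `COc1c(C)cnc(CN2c3nc(N)nc(Cl)c3NC(=O)[C@H]2C)c1C` gives 410 nM
compound 3 `COc1c(C)cnc(CN2CC(=O)N(C(C)C)c3c(Cl)nc(N)nc32)c1C` gives 30 nM

In a functional assay on BT-474 cells (Homo sapiens) for inhibition (a higher number here means a weaker inhibitor, a lower number a stronger inhibitor), compound 2 has the highest number of the three, and its gaps to compound 1 and to compound 3 both lie beyond the usual scatter, so it is the weakest inhibitor shown. Compound 4 `COc1c(C)cnc(CN2c3nc(N)nc(Cl)c3NC(=O)[C@@H]2C)c1C` is its mirror image: the two compounds have the same atoms and bonds and differ only in configuration as drawn: 1 of 1 stereo elements differ; a stereocentre at a saturated ring carbon is drawn R in compound 2 and S in compound 4. For the measured compounds named here, no measured pair here shows what such a swap does, so the size and direction of the step in this assay cannot be read from the data. Mirror-image pairs often differ well beyond the scatter, and compound 4 is expected to give a lower number, with wide uncertainty. For compound 4 the estimate is 150 nM (range 20 nM to 1500 nM), an expected step of a 2.7-fold lower number from compound 2 to compound 4 (0.44 log units; beyond the scatter).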

Compound 4, half-maximal inhibitory concentration: 470 nM
For compound 4 the middle estimate is 3.1-fold (0.50 log units) below the measured one, within the range that was stated.
By their numbers in this assay, from the lowest: compound 3; then compound 1; then compounds 2 and 4 (each within the scatter of the next).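

In this assay, turning the stereocentre at the saturated ring carbon from R to S gives a 1.1-fold higher number from compound 2 to compound 4 (0.06 log units; within the scatter), so the two mirror images cannot be told apart in this assay. For the compounds shown here, this is the first comparison here that isolates a single change, and it can be read as a test of configuration alone because of one fact: the fact that compounds 2 and 4 differ only in the configuration as drawn. For this pair, the drawn configuration at this carbon does not separate the numbers.

As far as these compounds go, what stays open is whether the same holds with a different group on this carbon, such as an ethyl chain or an amine. The compounds shown contain no such pair of mirror images.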